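This account rests on a few compounds, and the source may have more. Where it says the series, first, only, none or still open, it means among the compounds named here.

Compound 1 `O=C(O)CCC/C=C\C[C@H]1/C(=N/OC(c2ccccc2)c2ccccc2)CC[C@@H]1NS(=O)(=O)c1ccc(Cl)cc1` and compound 2 `Cc1ccc(S(=O)(=O)N[C@H]2CC/C(=N\OC(c3ccccc3)c3ccccc3)[C@@H]2C/C=C\CCCC(=O)O)cc1` share one core and differ only by methyl in place of chloro on an aromatic carbon. In a functional assay (plasma) for inhibition, with Homo sapiens as the target (on this read-out lower numbers stand for stronger inhibition and higher numbers for weaker inhibition), compound 1 gives 17000 nM, while compound 2 gives 5600 nM; this change brought a 3.0-fold lower number from compound 1 to compound 2 (0.48 log units; beyond the scatter). Compound 3 `O=C(O)CCC/C=C\C[C@H]1C(=O)CC[C@@H]1NS(=O)(=O)c1ccc(Cl)cc1` is built on another core, and how that core differs from the core of compound 1 is not broken down here. In this assay compound 3 gives 640 nM, the lowest of the three numbers. Compound 4 `Cc1ccc(S(=O)(=O)N[C@H]2CCC(=O)[C@@H]2C/C=C\CCCC(=O)O)cc1` is related to compound 3 by methyl in place of chloro on an aromatic carbon, the same change at the same place that turned compound 1 into compound 2. Because the earlier step of a 3.0-fold lower number from compound 1 to compound 2 (0.48 log units; beyond the scatter) was modest yet beyond the scatter, a step of similar size is expected for compound 4, namely a 2.6-fold lower number from compound 3 to compound 4 (0.41 log units; beyond the scatter). Compound 4 is therefore estimated to give 250 nM in this assay, most likely between 100 nM and 650 nM.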

Compound 4, half-maximal inhibitory concentration: 670 nM
The estimate for compound 4 lay 2.7-fold (0.43 log units) below the measured number; measured number above the stated range.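

In this assay, methyl in place of chloro brought a 1.0-fold higher number from compound 3 to compound 4 (0.02 log units; within the scatter), so the change that registered on the core of compound 1 did not carry over to the core of compound 3. The two steps do not agree: the same change on two cores in this assay, a 3.0-fold lower number (0.48 log units; beyond the scatter) from compound 1 to compound 2 and a 1.0-fold higher number (0.02 log units; within the scatter) from compound 3 to compound 4, 3.2-fold (0.50 log units) apart, beyond the scatter of two such steps. This shows that the step cannot be assumed to transfer between these two cores, but two pairs do not show what in the cores sets the gap or how the change would behave on any further core.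

The compounds shown leave open whether another group in the same place, such as methoxy or an amine, would also separate the two cores. They also leave open whether a carboxylic acid chain of another length would alter the gap.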